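The source may hold more compounds than are shown below. What is called first, only, known or untested is meant among the compounds shown, and "the series" means these compounds.

Measured so far in a functional assay on HCC 2998 cells (Homo sapiens) for antiproliferative activity; on this read-out lower numbers stand for stronger inhibition of growth and higher numbers for weaker inhibition of growth:

- compound 1 `COc1ccc(-c2nc3ccccc3s2)cc1OC` gives 42500 nM
- compound 2 `COc1ccc(-c2nc3cc(F)ccc3s2)cc1F` gives 13700 nM

Compound 2 holds the lower of the two numbers; compound 1 stands beyond the scatter above it, so compound 2 is the stronger of the pair on this read-out. Both numbers are weak in absolute terms.

Compound 3 `COc1ccc(-c2nc3cc(F)ccc3s2)cc1O` has not been measured. It differs from compound 2 in one place: hydroxy in place of fluoro on an aromatic carbon. The change sits ortho to a methoxy group and meta to a large group. Among the measured compounds shown here, no pair of measured compounds differs by this exchange, so there is no measured step to lean on; the two values shown say nothing about hydroxy in place of fluoro at this site.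

The expected step is a 1.1-fold higher number from compound 2 to compound 3 (0.04 log units; within the scatter), taken as no change beyond the scatter in either direction. Compound 3 is therefore estimated at 15000 nM, with a range from 4000 nM to 50000 nM.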

Compound 3, concentration for 50% growth inhibition: 7600 nM
Compound 3: the middle estimate sits 2.0-fold (0.30 log units) above what was measured, within the range that was stated.
By their numbers in this assay, from the lowest: compounds 3 and 2 (each within the scatter of the next); then compound 1.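

In this assay, hydroxy in place of fluoro on an aromatic carbon, ortho to a methoxy group and meta to a large group, gives a 1.8-fold lower number from compound 2 to compound 3 (0.26 log units; within the scatter). Among the compounds shown here, this is the only measured reading of this exchange, and it shows that the site takes a hydroxy, with its hydrogen-bond donor and acceptor, without a step beyond the scatter. No measurement at hand accounts for this reading, so it stands as an observation only.

The compounds shown leave open whether an amine or a carboxylic acid on this aromatic carbon would give a step beyond the scatter. Also open, on these data alone, is whether hydroxy in place of fluoro reads the same at other sites of the shared core.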